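A Methyl Added to the Anilide of Compound 3

The source may report more compounds than this note shows. Statements on the series, on what has been measured and on what is new or still open speak of the compounds shown alone.

Compound 1, `COc1cc(-c2nnc(SCC(=O)c3ccccc3)n2N)cc(OC)c1OC`: 53000 nM
Compound 2, `COc1cc(-c2nnc(SCC(=O)c3ccc(C)cc3)n2N)cc(OC)c1OC`: 370 nM
Compound 3, `COc1cc(-c2nnc(SCC(=O)Nc3ccccc3)n2N)cc(OC)c1OC`: 1730 nM

These three compounds were tested in a functional assay on HCT-116 cells (Homo sapiens) for antiproliferative activity, read by MTT assay, with a stated time of 48 h; on this read-out higher numbers stand for weaker inhibition and lower numbers for stronger inhibition. Among the compounds with values here, the only change from compound 1 to compound 2 is methyl in place of hydrogen on an aromatic carbon, and it gave a 140-fold lower number from compound 1 to compound 2 (2.16 log units; beyond the scatter). Compound 3 differs from compound 1 in its core by anilino in place of phenyl on a carbonyl carbon, a change that gave a 31-fold lower number from compound 1 to compound 3 (1.49 log units; beyond the scatter). Between compound 2 and compound 3 the step was a 4.7-fold higher number from compound 2 to compound 3 (0.67 log units; beyond the scatter).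

Compound 4, `COc1cc(-c2nnc(SCC(=O)Nc3ccccc3C)n2N)cc(OC)c1OC`, has not yet been measured in this assay. It differs from compound 3 by methyl in place of hydrogen on an aromatic carbon. This is the same kind of change as that from compound 1 to compound 2, but not the same: there the methyl sat para to a large group, here it sits ortho to a large group, and the cores differ as described.

Within the data shown here, with only one earlier instance, on a different core and at a different place, the step from compound 3 to compound 4 is expected to be smaller than the earlier one, estimated at a 2.9-fold lower number from compound 3 to compound 4 (0.46 log units; beyond the scatter). Compound 4 is thus expected to give about 600 nM in this assay, most likely between 150 nM and 2500 nM.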

Compound 4, half-maximal inhibitory concentration: > 100000 nM
Compound 4 ended at the assay's limit; the forecaster's own chance of this, stated with the estimate: 2%; middle value at least 160-fold (2.22 log units) away from the limit.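

Compound 4 gave > 100000 nM in this assay, which is a limit of the assay and not a number. Even so, the methyl change did not carry over from one core to the other, since an at least 57-fold higher number from compound 3 to compound 4 (1.76 log units; beyond the scatter) runs against the earlier step: the same change on two cores in this assay, a 140-fold lower number (2.16 log units; beyond the scatter) from compound 1 to compound 2 and an at least 57-fold higher number (1.76 log units; beyond the scatter) from compound 3 to compound 4, at least 8200-fold (3.91 log units) apart, beyond the scatter of two such steps Beside it stand an at least 270-fold higher number from compound 2 to compound 4 (2.43 log units; beyond the scatter) and an at least 1.8-fold higher number from compound 1 to compound 4 (0.27 log units; that floor lies within the scatter), but the core and the place of the methyl both differ between the two instances, so these compounds do not show which of the two accounts for the reversal, nor how far past the limit compound 4 lies.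

On these data alone, a (4-methylphenyl)amino group in place of the anilino of compound 3, or a 2-methylphenyl group in place of the phenyl of compound 1, would be needed to separate core from place, and how either behaves remains open. Also open, as far as these compounds go, is whether a chlorine or a methoxy group at the place of the methyl in compound 4 would give the same result.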